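From furan to thiophene at the saturated ring carbon

A few compounds are considered here, and "the series" means these few. Any claim that something is new, unique, unknown or untested is made for them only; others in the source may bear on it.

Compound 3 `CC1=C(C(=O)OCC2CC2)C(c2ccco2)NC(=O)N1` gives 29% in an assay on membranes from CHO cells for displacement of a labelled ligand from adenosine receptor A1 (Homo sapiens), read by scintillation counting, with a stated time of 60 min, tested at 1 uM; a lower number here means less inhibition, a higher number more inhibition at the concentration tested (going by the name of the read-out). Among the three measured compounds it stands second highest: compound 1 `CCCOC(=O)C1=C(C)NC(=O)NC1c1cccs1` gives 43%, and compound 2 `CC1=C(C(=O)SC(C)C)C(c2cccs2)NC(=O)N1` gives 1%. Going by the values given here, the one measured step, a number 42 percentage points lower from compound 1 to compound 2 (beyond the scatter), concerns the group on the carbonyl carbon and does not bear on the change at hand. Compound 4 `CC1=C(C(=O)OCC2CC2)C(c2cccs2)NC(=O)N1` differs from compound 3 by thiophen-2-yl in place of furan-2-yl on a saturated ring carbon. Among the compounds with values here, no measured pair shows this swap by itself; compound 1, which carries thiophen-2-yl with a different ester, gives a somewhat higher number than compound 3. The step of a number 9 percentage points higher from compound 3 to compound 4 (within the scatter) is therefore expected to stay within the scatter, perhaps slightly upward. Compound 4 is estimated at 38%, with a range from 20% to 56%.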

Compound 4, a percentage reported as inhibition, at one concentration (the size of the read-out at that concentration, not a potency): 23%
Compound 4: the middle estimate sits 15 percentage points above what was measured; the measured number falls inside the stated range.
By their numbers in this assay, from the lowest: compound 2; then compounds 4 and 3 (each within the scatter of the next); then compound 1.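

Thiophen-2-yl in place of furan-2-yl on the saturated ring carbon gives a number 6 percentage points lower from compound 3 to compound 4 (within the scatter) in this assay and so the two rings cannot be told apart at this position with this ester. With thiophen-2-yl held fixed, the ester side still counts: the carbonyl group's substituent gives a number 22 percentage points higher from compound 2 to compound 4 (beyond the scatter) when cyclopropylmethoxy replaces isopropylsulfanyl and a number 20 percentage points lower from compound 1 to compound 4 (beyond the scatter) when cyclopropyl replaces ethyl on the chain. Nothing available explains these differences.

From the compounds shown here alone, whether phenyl or a longer chain on that ring carbon would read the same remains open, as does whether the furan-to-thiophene swap holds with other esters.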